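This account rests on a few compounds, and the source may have more. Where it says the series, first, only, none or still open, it means among the compounds named here.

In a functional assay on KG-1 cells (Homo sapiens) for antiproliferative activity (on this read-out higher numbers stand for an effect only at larger amounts of compound and lower numbers for an effect already at smaller amounts), compound 1, with the structure `CC(C)(C#N)CC#Cc1c(Cl)c2c(Cl)cc(C(N)=O)nc2n1[C@H]1CCCNC1`, gives 113 nM, the lowest of the two single numbers available. Among the compounds with values here, compound 2, `NC(=O)c1cc(Cl)c2c(Cl)c(C#CCO)n([C@H]3CCCNC3)c2n1`, gives 301 nM, and the only change between them is a 2.7-fold higher number from compound 1 to compound 2 (0.43 log units; beyond the scatter). Compound 3, `NC(=O)c1cc(Cl)c2c(Cl)c(C#CC3COCCO3)n([C@H]3CCCNC3)c2n1`, has repeat entries and gives 77 nM; 203 nM (2 entries); the spread between these repeat entries of compound 3, (the several entries of compound 3 in this assay, 77 nM; 203 nM (2 entries)), shows how far two measurements of the same compound can lie apart.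

Compound 4, `COCCC#Cc1c(Cl)c2c(Cl)cc(C(N)=O)nc2n1[C@H]1CCCNC1`, is not yet measured. It differs from compound 1 by methoxymethyl in place of 1-cyano-1-methylethyl on a saturated chain carbon bound to a triple-bonded carbon. Within the data shown here, the only step that bears on this change is the one from compound 1 to compound 2, where a hydroxy on the same saturated chain carbon raised the number by a modest amount, just beyond the scatter. The methoxymethyl group of compound 4 is again smaller than the 1-cyano-1-methylethyl group it replaces, and so a step of similar direction, though perhaps smaller, is expected, giving an estimated 1.6-fold higher number from compound 1 to compound 4 (0.20 log units; within the scatter). Compound 4 is therefore expected to give about 180 nM in this assay, with a likely range from 70 nM to 450 nM.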

Compound 4, half-maximal effective concentration: 39 nM
Beside the measured number, compound 4's estimate is 4.6-fold (0.66 log units) above it, outside the stated range (below it).
By their numbers in this assay, from the lowest: compound 4; then compound 1; then compound 2.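

In this assay, methoxymethyl in place of the larger 1-cyano-1-methylethyl gives a 2.9-fold lower number from compound 1 to compound 4 (0.46 log units; beyond the scatter), so a smaller group on this saturated chain carbon does not by itself bring a higher number, as the step to hydroxy alone might have suggested. The two smaller groups also part widely, with methoxymethyl in place of hydroxy giving a 7.7-fold lower number from compound 2 to compound 4 (0.89 log units; beyond the scatter), so size alone does not order these compounds: compound 2 fits a rule that smaller is worse, and compound 4 goes against it. Repeat entries of a single compound can also lie well apart, so the exact sizes of these steps deserve cautious reading: the several entries of compound 3 in this assay, 77 nM; 203 nM (2 entries)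

Three groups at this position cannot show whether the lower number of compound 4 depends on the oxygen of methoxymethyl or simply on the length of its chain. A propyl group, with carbon in place of that oxygen, or a dimethylaminomethyl group, with an amine there instead, on the same saturated chain carbon would help to tell these readings apart.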